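Hydroxy for chloro in a level pair

A few compounds are considered here, and "the series" means these few. Any claim that something is new, unique, unknown or untested is made for them only; others in the source may bear on it.

In a functional assay on K562 cells (Homo sapiens) for inhibition, read by MTT assay (on this read-out lower numbers stand for stronger inhibition and higher numbers for weaker inhibition), compound 1 `CC(C)c1ccc(C(C)c2nnc(NC(=O)CCC(=O)NO)s2)cc1` gives 14700 nM. Compound 2 `O=C(CCC(=O)Nc1nnc(-c2ccc(Cl)cc2)s1)NO` gives 14700 nM, so it stands level with compound 1, and these two values offer no ranking. Compound 3 `O=C(CCC(=O)Nc1nnc(-c2ccc(O)cc2)s1)NO` has not yet been measured. It differs from compound 2 in one place, with hydroxy in place of chloro on an aromatic carbon. Among the compounds with values here, no measured step guides this swap, so no change beyond the scatter is expected, and the estimated 1.0-fold higher number from compound 2 to compound 3 (0.01 log units; within the scatter) stays within it. For compound 3 the estimated value is 15000 nM, with an expected range from 6000 nM to 40000 nM.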

Compound 3, half-maximal inhibitory concentration: 14700 nM
For compound 3 the middle estimate is 1.0-fold (0.01 log units) above the measured one; the measured number falls inside the stated range.
By their numbers in this assay, from the lowest: compounds 1, 2 and 3 (each within the scatter of the next).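

In this assay the change from 4-chlorophenyl to 4-hydroxyphenyl brings no change at the digits printed from compound 2 to compound 3 (within the scatter) on this read-out. Within the data shown here, this is the first single-place comparison, and it shows that the hydrogen-bond donor and acceptor entering with hydroxy leave the number where it stood with chloro. Nothing at hand explains why the two groups read alike. As far as these compounds go, whether an amine or a carboxylic acid on the same aromatic carbon would also leave the number unmoved stays open.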